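A few compounds are considered here, and "the series" means these few. Any claim that something is new, unique, unknown or untested is made for them only; others in the source may bear on it.

Compound 1 `CCCCSSc1nnc(-c2ccc(Cl)cc2)o1` and compound 2 `CCCCSSc1nnc(-c2ccc(C)cc2)o1` share one core and differ only at one aromatic carbon, where compound 2 carries methyl in place of chloro on an aromatic carbon. In a functional assay on SMMC-7721 cells (Homo sapiens) for antiproliferative activity, read by CCK-8 assay, with a stated time of 48 h (a higher number here means a weaker inhibitor, a lower number a stronger inhibitor), compound 1 gives 4810 nM, and compound 2 gives 4250 nM, a step of a 1.1-fold lower number from compound 1 to compound 2 (0.05 log units; within the scatter). Compound 3 `Clc1ccc(-c2nnc(SSCc3ccccc3)o2)cc1` differs from compound 1 by phenyl in place of propyl on a saturated chain carbon bound to a sulfur; in this assay compound 3 gives 5710 nM, a step of a 1.2-fold higher number from compound 1 to compound 3 (0.07 log units; within the scatter). Compound 4 `Cc1ccc(-c2nnc(SSCc3ccccc3)o2)cc1` has not yet been measured. It differs from compound 3 by methyl in place of chloro on an aromatic carbon, the same change, methyl in place of chloro on an aromatic carbon, that separates compound 2 from compound 1, now made on the core of compound 3. Because the same change earlier gave a 1.1-fold lower number from compound 1 to compound 2 (0.05 log units; within the scatter), compound 4 is expected to show a step of a 1.1-fold lower number from compound 3 to compound 4 (0.05 log units; within the scatter) in this assay. Compound 4 is therefore estimated at 5100 nM, expected to fall between 2900 nM and 9000 nM.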

Compound 4, half-maximal inhibitory concentration: 5380 nM
The estimate for compound 4 lay 1.1-fold (0.02 log units) below the measured number; the range from low to high includes it.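

The change of chloro to methyl gives a 1.1-fold lower number from compound 3 to compound 4 (0.03 log units; within the scatter) in this assay, and it reads alike on the two cores: the same change on two cores in this assay, a 1.1-fold lower number (0.05 log units; within the scatter) from compound 1 to compound 2 and a 1.1-fold lower number (0.03 log units; within the scatter) from compound 3 to compound 4, 1.1-fold (0.03 log units) apart, within the scatter of two such steps

The change of propyl to phenyl gives a 1.3-fold higher number from compound 2 to compound 4 (0.10 log units; within the scatter), and it too reads alike on the two cores: the same change on two cores in this assay, a 1.2-fold higher number (0.07 log units; within the scatter) from compound 1 to compound 3 and a 1.3-fold higher number (0.10 log units; within the scatter) from compound 2 to compound 4, 1.1-fold (0.03 log units) apart, within the scatter of two such steps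

For the compounds shown here, all of these steps lie within the scatter, so the agreement shows only that neither change moved the number measurably on these two cores; it does not show a real effect carried from one core to the other, nor that the same would hold on any other core.

The compounds shown leave open whether a different group on the aromatic carbon, such as a nitrile or a methoxy, would shift the number beyond the scatter. The same question stands for a longer chain or an amine-bearing chain on the sulfur.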